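Shortening the chain: compound 3 rearranged into compound 4

The source may hold more compounds than are shown below. What is called first, only, known or untested is meant among the compounds shown, and "the series" means these compounds.

In an assay on THP-1 cells for displacement of a labelled ligand from C-C chemokine receptor type 1 (Homo sapiens) (on this read-out lower numbers stand for stronger inhibition and higher numbers for weaker inhibition), compound 1 `Cc1ccc(C(=O)N[C@@H](C(=O)N2CCC(c3ccc(Cl)cc3)CC2)C(C)C)cc1` gives 25 nM, and compound 2 `CC(C)CC(=O)N[C@@H](C(=O)N1CCC(c2ccc(Cl)cc2)CC1)C(C)C` gives 32 nM. Compound 3 `CC(C)[C@@H](NC(=O)CCCc1ccccc1)C(=O)N1CCC(c2ccc(Cl)cc2)CC1` gives 95 nM, the highest number of the three, and its two steps from the others are both beyond the scatter: a 3.8-fold higher number from compound 1 to compound 3 (0.58 log units; beyond the scatter) and a 3.0-fold higher number from compound 2 to compound 3 (0.47 log units; beyond the scatter), while the pair of compound 1 and compound 2 sits within the scatter, a 1.3-fold higher number from compound 1 to compound 2 (0.11 log units; within the scatter). Compound 4 `Cc1cccc(CCC(=O)N[C@@H](C(=O)N2CCC(c3ccc(Cl)cc3)CC2)C(C)C)c1` has the same atoms as compound 3 joined differently: 3-methylphenyl in place of benzyl on a saturated chain carbon, two bonds along the chain from a carbonyl carbon. For the measured compounds named here, the steps that bear on this are the two into compound 3, both modest, in which a longer chain carrying a phenyl gave a higher number than a shorter substituent. Since compound 4 moves the ring one bond closer to the carbonyl, the expectation is a modest step back toward the numbers of compound 1 and compound 2, estimated as a 1.7-fold lower number from compound 3 to compound 4 (0.24 log units; within the scatter). For compound 4 in this assay the estimate is 55 nM, with a range from 20 nM to 150 nM.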

Compound 4, half-maximal inhibitory concentration: 22 nM
Compound 4: the middle estimate sits 2.5-fold (0.40 log units) above what was measured, within the range that was stated.
By their numbers in this assay, from the lowest: compounds 4, 1 and 2 (each within the scatter of the next); then compound 3.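

Exchanging the 3-phenylpropyl chain for 2-(3-methylphenyl)ethyl, with the same atoms joined differently, gives in this assay a 4.3-fold lower number from compound 3 to compound 4 (0.64 log units; beyond the scatter), so the higher number of the earlier chain belongs to that particular arrangement and not to its atoms as such. The other two steps, a 1.5-fold lower number from compound 2 to compound 4 (0.16 log units; within the scatter) and a 1.1-fold lower number from compound 1 to compound 4 (0.06 log units; within the scatter), both lie within the scatter, which shows that a chain carrying an aromatic ring need not give a higher number on this read-out. Nothing in the data at hand accounts for the difference between the two arrangements.

The compounds shown do not separate the shorter chain from the methyl, and a 2-phenylethyl chain without the methyl would tell the two apart. Going by these compounds, whether a chlorine or a methoxy group in place of that methyl keeps the number also stays open.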